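The compounds below may be only part of what the source reports. "The series", "measured", "known", "first", "only" and "open" are said of these compounds alone.

Compound 1 `C/C(=C\c1cc(-c2ccc(C)cc2)co1)C(N)=O`: in a functional assay on BGC-823 cells (Homo sapiens) for cytotoxicity, read by CCK-8 assay, with a stated time of 24 h (on this read-out lower numbers stand for stronger inhibition and higher numbers for weaker inhibition), compound 1 gives > 50000 nM, which is a limit and not a number.
Compound 2 `C/C(=C\c1cc(-c2cccnc2)co1)C(N)=O`: in this assay compound 2 gives > 50000 nM, likewise a limit.

Compound 2 thus stands at the ceiling of what was resolved, the point where both measured values sit (the limit of > 50000 nM in this assay, at which 2 of the 2 values shown sit). Compound 3 `C/C(=C\c1cc(-c2ccc(F)nc2)co1)C(N)=O` differs from compound 2 by fluoro in place of hydrogen on an aromatic carbon. Among the compounds with values here, no measured step exists to guide the size of this change, and both known values are limits, so no step beyond the scatter is expected in this assay; the expected step that the limit leaves unreadable from compound 2 to compound 3 is essentially none. Compound 3 is expected to give 60000 nM in this assay, within 20000 nM to 200000 nM, most likely again reported as a limit.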

Compound 3, half-maximal inhibitory concentration: > 50000 nM
Compound 3: only a limit was reported; the forecaster's own chance of this, stated with the estimate: 85%; the middle value does not contradict the limit.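

Compound 2 and compound 3 both sit at a limit, so no step between them can be read: the limit of > 50000 nM in this assay, at which 3 of the 3 values shown sit.

The compounds shown leave open whether fluoro in place of hydrogen has any effect in this assay.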